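This account rests on a few compounds, and the source may have more. Where it says the series, first, only, none or still open, it means among the compounds named here.

Two measured compounds share one core and differ only in the group carried by the chain on the saturated ring carbon. Compound 1 `O=S(=O)(O)CCCNC[C@@H]1CCCc2cc(S(=O)(=O)c3cccc(F)c3)ccc21` gives 1.26 nM in an assay on isolated protein for displacement of a labelled ligand from 5-hydroxytryptamine receptor 6 (Homo sapiens); on this read-out lower numbers stand for stronger inhibition and higher numbers for weaker inhibition. Compound 2 `NCC(=O)NC[C@@H]1CCCc2cc(S(=O)(=O)c3cccc(F)c3)ccc21` gives 0.316 nM in this assay. Among the compounds with values here, the single step connecting them, a 4.0-fold lower number from compound 1 to compound 2 (0.60 log units; beyond the scatter), is the only movement seen so far, so compound 2 stands at the lower of the two numbers and compound 1 at the nearest higher one.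

Compound 3 `N=C(N)NC(=O)C[C@@H]1CCCc2cc(S(=O)(=O)c3cccc(F)c3)ccc21` takes the change a stage further: a group of 6 heavy atoms (2 carbon, 3 nitrogen, 1 oxygen; no ring) in place of a group of 5 heavy atoms (2 carbon, 2 nitrogen, 1 oxygen; no ring), on a saturated chain carbon bound to a saturated ring carbon. Within the data shown here, the measured step exchanged one substituent for another on an amine nitrogen that stayed in place; the change to compound 3 removes that amine nitrogen as well, so no measured step bears on it directly, and the numbers for compound 1 and compound 2 only show that this region tolerates variation within a modest span. The step from compound 2 to compound 3 is therefore expected to be small, a 1.9-fold higher number from compound 2 to compound 3 (0.28 log units; within the scatter), with no firm direction beyond the scatter. Compound 3 is expected to give 0.6 nM in this assay, within a range of 0.15 nM to 3 nM.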

Compound 3, inhibition constant: 0.631 nM
Compound 3: the middle estimate sits 1.1-fold (0.02 log units) below what was measured; measured number inside the range.
By their numbers in this assay, from the lowest: compounds 2, 3 and 1 (each within the scatter of the next, the first and the last beyond it).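

In this assay, the amine nitrogen of the chain is not needed for a number in the range of compound 2: removing it along with the ((aminomethyl)carbonyl)amino group, on a saturated chain carbon bound to a saturated ring carbon, gives a 2.0-fold higher number from compound 2 to compound 3 (0.30 log units; within the scatter). Set against the 3-sulfopropyl compound, the same place gives a 2.0-fold lower number from compound 1 to compound 3 (0.30 log units; within the scatter), so compound 3 stands within the scatter of both neighbours, even though those two are separated by a step beyond it. Two quite different groups at this place, one of them no longer attached through that amine nitrogen, therefore leave the number in one narrow span, and nothing available here explains why.

The three compounds do not show whether this span would hold for a plain primary amine, a carboxylic acid or a longer chain at this place, or for a group containing a ring such as piperazine. They also leave open how the number would respond to the opposite configuration at the saturated ring carbon, since all three share one configuration there.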